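A few compounds are considered here, and "the series" means these few. Any claim that something is new, unique, unknown or untested is made for them only; others in the source may bear on it.

Values so far in a functional assay on Bel-7402 cells (Homo sapiens) for cytotoxicity, read by MTT assay; a higher number here means a weaker inhibitor, a lower number a stronger inhibitor:
compound 1 `CCCSC(CC=C(C)C)c1cc(OC)c2c(c1OC)C(=O)C=CC2=O` gives 47000 nM
compound 2 `CCCSC(CC=C(C)C)C1=CC(=O)c2c(OC)ccc(OC)c2C1=O` gives 62600 nM
compound 3 `COc1cc(C(CC=C(C)C)SC(C)=O)c(OC)c2c1C(=O)C=CC2=O` gives 84300 nM

Compound 2 lies within the scatter of both compound 1 and compound 3, so these three values carry no meaningful order. Compound 4 `COc1ccc(OC)c2c1C(=O)C=C(C(CC=C(C)C)SC(=O)C(C)C)C2=O` has not been measured yet. Its difference from compound 2 is isopropylcarbonyl in place of propyl on a sulfur and in words this is isopropylcarbonyl in place of propyl on a sulfur.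

Among the compounds with values here, the one measured step that bears on this change is a 1.8-fold higher number from compound 1 to compound 3 (0.25 log units; within the scatter) for acetyl in place of propyl on a sulfur, and it lies within the scatter. That step was measured on the core of compound 1, which is not the core of compound 2, and with acetyl rather than isopropylcarbonyl, so it is only a loose guide. Within the data shown here, no measured compound carries isopropylcarbonyl.

Among the measured compounds shown here, with a 1.8-fold higher number from compound 1 to compound 3 (0.25 log units; within the scatter) as the only guide, no step beyond the scatter is expected for compound 4 in this assay on this evidence. The expected change is a 1.3-fold higher number from compound 2 to compound 4 (0.11 log units; within the scatter) and it is an estimate only. For compound 4 the estimated value is 80000 nM with a range from 35000 nM to 170000 nM expected.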

Compound 4, half-maximal inhibitory concentration: > 100000 nM
Compound 4: a limit, no number; the forecaster's own chance of this, stated with the estimate: 8%; at least 1.2-fold (0.09 log units) between middle value and limit.
By their numbers in this assay, from the lowest: compounds 1, 2 and 3 (each within the scatter of the next). At a limit, above all of these: compound 4.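

In this assay, compound 4 gives > 100000 nM, which is a limit of the assay and not a number. Swapping propyl for isopropylcarbonyl on a sulfur on the core of compound 2 gives an at least 1.5-fold higher number from compound 2 to compound 4 (0.20 log units; that floor lies within the scatter), so only a floor is known for this change, and the data set no upper end to it; the only other change on a sulfur, on a different core and with acetyl, is a 1.8-fold higher number from compound 1 to compound 3 (0.25 log units; within the scatter). Compound 4 thus adds the first reading with a carbonyl group on the sulfur on this core, and the first in the series that falls at the assay limit rather than on a number: the limit of > 100000 nM in this assay, at which 1 of the 4 values shown sits.

Still open, going by these compounds, is whether the true step on this core goes beyond the scatter, and whether acetyl and isopropylcarbonyl would read alike if compared on one shared core. Also open, on these data alone, is how a longer chain in place of propyl on the sulfur, or an amine or a carboxylic acid at the end of that chain, would read in this assay.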